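Benzyl in place of methyl on a selenium-bearing acylated amidine

The compounds below may be only part of what the source reports. "The series", "measured", "known", "first", "only" and "open" are said of these compounds alone.

Measured compounds:
compound 1 `C[Se]/C(=N\C(=O)c1ccco1)NC(=O)c1ccco1` — 88900 nM
compound 2 `O=C(/N=C(/NC(=O)c1cccs1)[Se]Cc1ccccc1)c1cccs1` — > 100000 nM
compound 3 `CS/C(=N\C(=O)c1cc(-c2ccccc2)nc2ccccc12)NC(=O)c1cc(-c2ccccc2)nc2ccccc12` — 87700 nM

All three were tested in a functional assay on MCF7 cells (Homo sapiens) for cytotoxicity, read by MTT assay, with a stated time of 72 h; on this read-out lower numbers stand for stronger inhibition of growth and higher numbers for weaker inhibition of growth. Compound 1 gives 88900 nM in this assay. Compound 3, built on a different core with sulfur in place of selenium, gives 87700 nM, and the two numbers lie within the usual scatter of each other, so nothing separates them. Compound 2 reaches only the limit of the assay, > 100000 nM, and so yields no number at all.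

Compound 4 `O=C(/N=C(/NC(=O)c1ccco1)[Se]Cc1ccccc1)c1ccco1` has not yet been measured. It differs from compound 1 by a single change: phenyl in place of hydrogen on a saturated chain carbon bound to a selenium atom, which read one bond further out is methyl to benzyl on the selenium atom. Among the measured compounds shown here, no pair of measured compounds shows this exact step, so its size must be guessed. Compound 2 also carries a benzyl group on its selenium atom, on a closely related core, and sits at the limit (the limit of > 100000 nM in this assay, at which 1 of the 3 values shown sits). The step from compound 1 to compound 4 is therefore expected to move toward weaker growth inhibition, likely beyond the scatter, as a 1.5-fold higher number from compound 1 to compound 4 (0.17 log units; within the scatter). Compound 4 is expected to give about 130000 nM in this assay, in a range from 60000 nM to 300000 nM, with a real chance that only a limit is reported.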

Compound 4, concentration for total growth inhibition: 58000 nM
Beside the measured number, compound 4's estimate is 2.2-fold (0.35 log units) above it; measured number outside the range, below it.
By their numbers in this assay, from the lowest: compounds 4, 3 and 1 (each within the scatter of the next). At a limit, above all of these: compound 2.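

In this assay, the swap of methyl for benzyl on the selenium atom, with the rest of compound 1 left as it is, gives a 1.5-fold lower number from compound 1 to compound 4 (0.19 log units; within the scatter) and leaves the two compounds impossible to tell apart. Among the compounds shown here, this is the first direct reading of this position, and it shows that a phenyl on the saturated chain carbon bound to the selenium atom can be carried by this core with a true number still returned and no loss of growth inhibition that stands clear of the scatter. Compound 2, which also has benzyl on its selenium atom, gives only a limit and not a number: the limit of > 100000 nM in this assay, at which 1 of the 4 values shown sits.

Going by these compounds, whether a different group at this position, such as a longer chain like butyl or a chain ending in an amine, would move the number beyond the scatter remains open. What the selenium atom itself contributes also stays unsettled, since compound 3 carries sulfur on a different core and so differs from compound 1 in more than one place.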